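The source may report more compounds than this note shows. Statements on the series, on what has been measured and on what is new or still open speak of the compounds shown alone.

Of the compounds shown here, two of a shared core have been measured so far in a physicochemical assay for lipophilicity, in phosphate buffer, measured as octanol-water partition, with a stated time of 24 h; a lower number here means a more polar compound, a higher number a more lipophilic compound. Compound 1 `O=C(CN1C(=O)c2ccccc2C1=O)NN1C(=O)CSC1c1cccnc1` gives 1.25 in this assay. Within the data shown here, compound 2 `O=C(CN1C(=O)c2ccccc2C1=O)NN1C(=O)CSC1c1ccco1` gives 1.13 in this assay, and the single measured step, a number 0.12 log units lower from compound 1 to compound 2 (within the scatter), exchanges one five-membered aromatic ring for another on a saturated ring carbon. On the numbers shown, compound 2 stands at the lower of the two values, though its gap to compound 1 lies within the scatter, so the two compounds cannot be ordered.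

The next compound, compound 3 `COc1ccc(C2SCC(=O)N2NC(=O)CN2C(=O)c3ccccc3C2=O)cc1OC`, differs from compound 2 in one place: 3,4-dimethoxyphenyl in place of furan-2-yl on a saturated ring carbon. Among the measured compounds shown here, the only measured step bears on it indirectly, as it too changes the group on that saturated ring carbon, but it swapped one five-membered aromatic ring for another of the same size and left the number essentially unchanged. The present change instead brings in a six-membered aromatic ring of carbon only, with two more heavy atoms than the group that leaves would predict and one more hydrogen-bond acceptor. For the measured compounds named here, no measured step covers such a change, so the expected step rests on the larger group alone. Compound 3 is expected to move upward, by an estimated a number 0.72 log units higher from compound 2 to compound 3 (beyond the scatter), beyond the scatter. The value of compound 3 in this assay is therefore estimated at 1.85, with a range from 1.4 to 2.3.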

Compound 3, partition coefficient: 2.78
Estimate against measurement, compound 3: 0.93 log units below, outside the stated range (above it).
By their numbers in this assay, from the lowest: compounds 2 and 1 (each within the scatter of the next); then compound 3.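

In this assay, the group on this saturated ring carbon turns out to matter a great deal: 3,4-dimethoxyphenyl in place of furan-2-yl gives a number 1.65 log units higher from compound 2 to compound 3 (beyond the scatter), and the same group in place of pyridin-3-yl gives a number 1.53 log units higher from compound 1 to compound 3 (beyond the scatter). Among these compounds, compound 1 and compound 2 showed only that one exchange at this position can leave no readable difference, whereas compound 3 shows that the same position can also carry a large step, with both new steps beyond the scatter. No measured evidence is available to account for the size of these steps.

Compound 3 brings in a six-membered ring of carbon only and two methoxy groups at once, so the compounds shown cannot divide the rise between the ring and those groups, and an unsubstituted phenyl ring or a phenyl ring with a single methoxy group would be needed to separate them. Also open, as far as these compounds go, is where a charged group at this position, such as an amine or a carboxylic acid on the phenyl ring, would fall on this scale.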